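Chain extension on the bromophenyl member of the series

The compounds below may be only part of what the source reports. "The series", "measured", "known", "first", "only" and "open" are said of these compounds alone.

Values in an ADME assay on BJ cells (Homo sapiens) for cytotoxicity, read by fluorescence, with a stated time of 24 h; on this read-out lower numbers stand for stronger inhibition and higher numbers for weaker inhibition:
- compound 1 `O=C(CC1S/C(=N\N=C\c2c(-c3ccccc3)[nH]c3ccccc23)NC1=O)c1ccccc1`: > 50000 nM (a limit)
- compound 2 `CC(=O)OCCC1S/C(=N\N=C\c2c(-c3ccccc3)[nH]c3ccccc23)NC1=O`: 37100 nM
- compound 3 `CC1S/C(=N\N=C\c2c(-c3ccc(Br)cc3)[nH]c3ccccc23)NC1=O`: > 50000 nM (a limit)

Compound 3 has no number, only a limit, and sits at the limit of > 50000 nM in this assay, at which 2 of the 3 values shown sit. The next compound, compound 4 `O=C1N/C(=N/N=C/c2c(-c3ccc(Br)cc3)[nH]c3ccccc23)SC1CCO`, differs from it by hydroxymethyl in place of hydrogen on a saturated chain carbon bound to a saturated ring carbon, which also reads as methyl to 2-hydroxyethyl.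

Among the compounds with values here, only one measured step bears on this change: an at least 1.3-fold lower number from compound 1 to compound 2 (0.12 log units; that floor lies within the scatter). It concerns a different pair of groups, and its floor lies within the scatter, so it gives no size or direction to carry over. No step beyond the scatter is therefore expected in this assay.

The expected step is an at least 1.1-fold lower number from compound 3 to compound 4 (0.04 log units; that floor lies within the scatter). Compound 4 is estimated at 45000 nM, with an expected range of 22000 nM to 70000 nM.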

Compound 4, half-maximal inhibitory concentration: 29200 nM
The estimate for compound 4 lay 1.5-fold (0.19 log units) above the measured number; the measured number falls inside the stated range.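

In this assay, within the data shown here, the first reading for methyl to 2-hydroxyethyl on this saturated chain carbon is an at least 1.7-fold lower number from compound 3 to compound 4 (0.23 log units; that floor lies within the scatter). Compound 4 gives a measured number in this pair, but the step remains a floor, so neither its full size nor a change beyond the scatter is established. For compound 3 the entry is only a limit, and this is not an isolated case among the compounds shown: the limit of > 50000 nM in this assay, at which 2 of the 4 values shown sit.

Open, on these data alone, is whether an amine, a carboxylic acid or a longer chain in place of 2-hydroxyethyl would give a step beyond the scatter. Also open, as far as these compounds go, is whether the hydroxymethyl change would read the same without the bromine, as compound 2 and compound 4 differ in more than one place and cannot be compared directly.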